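Triple-bonded aryl variants on the shared core

The source may hold more compounds than are shown below. What is called first, only, known or untested is meant among the compounds shown, and "the series" means these compounds.

Compound 1 `COC(=O)c1sc2cc(C#Cc3ccc(N)cc3)cnc2c1N`: 2600 nM
Compound 2 `COC(=O)c1sc2cc(C#Cc3ccccc3F)cnc2c1N`: reported only as a limit, > 150000 nM
Compound 3 `COC(=O)c1sc2cc(C#Cc3ccsc3)cnc2c1N`: 27700 nM

In a functional assay on MCF7 cells (Homo sapiens) for inhibition, read by sulforhodamine B assay, with a stated time of 48 h (a lower number here means a stronger inhibitor of growth, a higher number a weaker inhibitor of growth), compound 1 holds the lowest of the two proper numbers, with compound 3 next, an 11-fold higher number from compound 1 to compound 3 (1.03 log units; beyond the scatter). Compound 4 `COC(=O)c1sc2cc(C#Cc3ccccc3)cnc2c1N` differs from compound 1 by hydrogen in place of amino on an aromatic carbon. Both measured replacements of the 4-aminophenyl weakened growth inhibition: an 11-fold higher number from compound 1 to compound 3 (1.03 log units; beyond the scatter) and an at least 57-fold higher number from compound 1 to compound 2 (1.76 log units; beyond the scatter). The second of these ends at the limit of the assay (the limit of > 150000 nM in this assay, at which 1 of the 3 values shown sits). The change to compound 4 retains the phenyl ring and alters only the amino, a smaller change than either measured step, so a rise in this assay is expected but a smaller one. Compound 4 is therefore estimated at 18000 nM (range 5000 nM to 70000 nM). This corresponds to an expected step of a 6.9-fold higher number from compound 1 to compound 4 (0.84 log units; beyond the scatter).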

Compound 4, concentration for 50% growth inhibition: > 150000 nM
Compound 4 gave a limit, no number; the forecaster's own chance of this, stated with the estimate: 10%; middle value at least 8.3-fold (0.92 log units) from the limit.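

Removing the amino while keeping the phenyl ring is enough to lose measurable growth inhibition in this assay, giving an at least 57-fold higher number from compound 1 to compound 4 (1.76 log units; beyond the scatter). The aryl ring alone therefore does not set the effect, and an unsubstituted ring is not uniformly inactive: thiophen-3-yl keeps a measurable value, with an at least 5.4-fold higher number from compound 3 to compound 4 (0.73 log units; beyond the scatter). Compound 4 is reported only as a limit, and its step from compound 2 cannot be read: the limit of > 150000 nM in this assay, at which 2 of the 4 values shown sit.

From the compounds shown here alone, whether the effect requires the amino itself remains open. A hydroxyl, methylamino or dimethylamino group on the same aromatic carbon would test this.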